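The source may hold more compounds than are shown below. What is called first, only, known or untested is meant among the compounds shown, and "the series" means these compounds.

Values in an ADME assay on HepG2 cells (Homo sapiens) for inhibition, with a stated time of 48 h; on this read-out higher numbers stand for an effect only at larger amounts of compound and lower numbers for an effect already at smaller amounts:
compound 1 `CC(C(=O)N1CCCCCC1)N1CCN(S(=O)(=O)c2ccc(C(C)(C)C)cc2)CC1`: > 40000 nM
compound 2 `CC(C(=O)N1CCC(F)(F)CC1)N1CCN(S(=O)(=O)c2ccc(C(C)(C)C)cc2)CC1`: > 40000 nM
compound 3 `CC(C(=O)N1CCC2(CC1)CC2)N1CCN(S(=O)(=O)c2ccc(C(C)(C)C)cc2)CC1`: > 40000 nM

Compound 3 gives only a limit, > 40000 nM, not a number. Compounds 1 and 2 share that position, as the limit of > 40000 nM in this assay, at which 3 of the 3 values shown sit, shows.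

Compound 4 `CC(C(=O)N1CCc2ccccc2C1)N1CCN(S(=O)(=O)c2ccc(C(C)(C)C)cc2)CC1` brings in 1,2,3,4-tetrahydroisoquinolin-2-yl, on a carbonyl carbon: a group of 10 heavy atoms (9 carbon, 1 nitrogen; one six-membered non-aromatic ring with 1 hetero atom, one six-membered aromatic ring of carbon only) in place of a group of 8 heavy atoms (7 carbon, 1 nitrogen; one three-membered non-aromatic ring of carbon only, one six-membered non-aromatic ring with 1 hetero atom), on a carbonyl carbon. Three measured steps changed the same place: a step that the two limits leave unreadable from compound 1 to compound 2, a step that the two limits leave unreadable from compound 1 to compound 3 and a step that the two limits leave unreadable from compound 2 to compound 3. Among the compounds with values here, none has a readable size, so none gives a direction, and the aromatic ring in compound 4 has no measured precedent here. The expected change is therefore none beyond the scatter: a number no higher from compound 3 to compound 4 (the limit leaves the size open). For compound 4 the estimate is 40000 nM, with an expected range from 15000 nM to 80000 nM.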

Compound 4, half-maximal effective concentration: 29000 nM
Beside the measured number, compound 4's estimate is 1.4-fold (0.14 log units) above it; the range from low to high includes it.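

Compounds 1, 2 and 3 all stay at a limit of this assay: the limit of > 40000 nM in this assay, at which 3 of the 4 values shown sit. Compound 4, with 1,2,3,4-tetrahydroisoquinolin-2-yl on the carbonyl carbon, is the only compound shown with a real number, which gives an at least 1.3-fold lower number from compound 3 to compound 4 (0.13 log units; that floor lies within the scatter), an at least 1.3-fold lower number from compound 2 to compound 4 (0.13 log units; that floor lies within the scatter) and an at least 1.3-fold lower number from compound 1 to compound 4 (0.13 log units; that floor lies within the scatter). Each of these is only a floor, and each floor lies within the scatter, so the true sizes may be larger but no real change is yet established. From the compounds shown here alone, how large these steps are stays open, as does whether an amine or a carboxylic acid on the aromatic ring of 1,2,3,4-tetrahydroisoquinolin-2-yl would change the number.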